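Trading an Ethynyl for a Methyl on the Aryl Ring

The source may hold more compounds than are shown below. What is called first, only, known or untested is meant among the compounds shown, and "the series" means these compounds.

Measured so far:
compound 1 `CC1SC(c2cccc(C(=O)NCCCCc3ccccc3)c2)N(c2ccc(C3CC3)cc2)C1=O` — 2000 nM
compound 2 `COc1ccccc1N1C(=O)C(C)SC1c1cccc(C(=O)NCCCCc2ccccc2)c1` — 10000 nM
compound 3 `C#Cc1cccc(N2C(=O)CSC2c2cccc(C(=O)NCCCCc3ccccc3)c2)c1` — 10000 nM

Of the compounds shown here, three built on a shared core have been read in a physicochemical assay for solubility, read by turbidimetry, measured as kinetic solubility, at pH 7.4; a higher number here means a more soluble compound, a lower number a less soluble compound. Going by the values given here, the one measured step among them, a 5.0-fold higher number from compound 1 to compound 2 (0.70 log units; beyond the scatter), follows the exchange of 2-methoxyphenyl for 4-cyclopropylphenyl on the amide-type nitrogen in the ring. Compound 3 stands level with compound 2 at the digits shown, and the two together hold the highest numbers of the three; compound 1 sits lower than compound 3, beyond the scatter.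

Compound 4 `Cc1cccc(N2C(=O)CSC2c2cccc(C(=O)NCCCCc3ccccc3)c2)c1` is the compound not yet measured. It differs from compound 3 in one place: methyl in place of ethynyl on an aromatic carbon. Among the compounds with values here, no measured step isolates this change. Within the data shown here, the only step available, a 5.0-fold higher number from compound 1 to compound 2 (0.70 log units; beyond the scatter), replaces the whole aryl group on the ring nitrogen and so does not speak to swapping methyl for ethynyl on an aromatic carbon. With nothing in the data pointing either way, compound 4 is expected to give no change at the digits printed from compound 3 to compound 4 (within the scatter), that is, no step beyond the scatter. The estimate for compound 4 in this assay is therefore 10000 nM, with a range from 4000 nM to 20000 nM.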

Compound 4, solubility: 10000 nM
Compound 4: middle estimate and measured number agree at the digits printed; measured number inside the range.
By their numbers in this assay, from the lowest: compound 1; then compounds 2, 3 and 4 (each within the scatter of the next).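

In this assay, the exchange of ethynyl for methyl on an aromatic carbon, meta to a large group, gives no change at the digits printed from compound 3 to compound 4 (within the scatter). Going by these compounds alone, this is the first reading of a change confined to this one substituent: the earlier measured step replaced the whole aryl group on the ring nitrogen, whereas here the ring stays in place and only the 3-ethynylphenyl becomes 3-methylphenyl, so the triple bond can leave this position with no step beyond the scatter in this pair. Nothing in the available data explains why the read-out holds across this exchange.

What this pair leaves open is whether the same holds for groups of a different kind at this position, such as an amine, a carboxylic acid or a longer chain, since ethynyl and methyl are the only two substituents compared here. It also remains open whether the exchange would read the same on the 4-cyclopropylphenyl series, where compound 1 gives 2000 nM, because no pair shown tests this change on any other aryl group.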